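The source may hold more compounds than are shown below. What is called first, only, known or untested is meant among the compounds shown, and "the series" means these compounds.

Working notes on the series.

Compound 1 `O=C(C=CNc1cc(-c2ccccc2)nn1-c1ccccc1)c1cccs1` has been measured in a functional assay on HepG2 cells (Homo sapiens) for inhibition, read by MTT assay, with a stated time of 48 h (a lower number here means a stronger inhibitor, a higher number a weaker inhibitor), and gives 2420 nM. Among the measured compounds shown here, this is the lowest of the three numbers so far in this assay. Compound 2 `N#Cc1c(-c2ccc(Cl)cc2)nc2c(c(-c3ccccc3)nn2-c2ccccc2)c1-c1ccc(N2CCCCC2)cc1` gives 3210 nM in this assay, a number that sits within the usual scatter of compound 1, so no order between the two can be read from these two values. Compound 3 `c1ccc(-c2nn(-c3ccccc3)c3nccc(-c4cccs4)c23)cc1` gives 39300 nM in this assay, a number well beyond the scatter from compound 1, so of the three compound 3 is clearly the weaker inhibitor against compound 1. For the measured compounds named here, no pair of measured compounds differs in a single place, so no single structural step has yet been put to a number.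

Compound 4 `Cc1ccc(C(=O)C=CNc2cc(-c3ccccc3)nn2-c2ccccc2)cc1` has not been measured in this assay. It differs from compound 1 in one place: 4-methylphenyl in place of thiophen-2-yl on a carbonyl carbon. The rest of the shared core of compound 1 is kept. Going by the values given here, nothing measured so far speaks to an exchange at this carbonyl carbon, so the expectation rests on the closeness of the two structures alone. The step from compound 1 to compound 4 is expected to be small, a 1.1-fold higher number from compound 1 to compound 4 (0.03 log units; within the scatter), with no direction that would stand out beyond the scatter. Compound 4 is therefore estimated at 2600 nM in this assay, within a range from 1000 nM to 6500 nM.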

Compound 4, half-maximal inhibitory concentration: 7320 nM
The estimate for compound 4 lay 2.8-fold (0.45 log units) below the measured number, outside the stated range (above it).
By their numbers in this assay, from the lowest: compounds 1 and 2 (each within the scatter of the next); then compound 4; then compound 3.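

Among the compounds shown here, the carbonyl carbon is the first place where a single exchange has been put to a number. In this assay the change to 4-methylphenyl in place of thiophen-2-yl gives a 3.0-fold higher number from compound 1 to compound 4 (0.48 log units; beyond the scatter) as a modest step beyond the scatter, so the read-out responds to the group at this position even with the rest of the shared core kept, and of this pair the thiophen-2-yl compound carries the lower number. Nothing at hand bears on the reason for this step, and the number alone gives no account of it.

The compounds shown leave open whether the step belongs to the change of ring or to the methyl group, a question that plain phenyl on the same carbonyl carbon would separate, with furan-2-yl as a further test of how much depends on the five-membered ring. Also open, going by these compounds, is how far the number moves with a group of another kind on this carbonyl carbon, such as an amine or a carboxylic acid carried on the phenyl ring.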